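Halogen pattern on the aryloxy tail: compound 3 to compound 4

This account rests on a few compounds, and the source may have more. Where it says the series, first, only, none or still open, it means among the compounds named here.

Measured so far in a functional assay on HCT-116 cells (Homo sapiens) for antiproliferative activity, read by MTT assay, with a stated time of 72 h; on this read-out higher numbers stand for weaker inhibition and lower numbers for stronger inhibition:
compound 1 `NC1=NC2(CCOCC2)N(OCCCOc2ccc(Cl)c(Cl)c2)C(N)=N1` gives 90 nM
compound 2 `NC1=NC2(CCOCC2)N(OCCCOc2ccc(F)cc2)C(N)=N1` gives 3280 nM
compound 3 `NC1=NC2(CCOCC2)N(OCCCOc2ccc(Cl)cc2)C(N)=N1` gives 690 nM

Compound 3 holds the middle position of the three: compound 1 lies below it by a 7.7-fold higher number from compound 1 to compound 3 (0.88 log units; beyond the scatter), and compound 2 above it by a 4.8-fold lower number from compound 2 to compound 3 (0.68 log units; beyond the scatter). Both measured steps concern the halogen on the aryl ring at the end of the chain, and both lie beyond the scatter, so changes here matter.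

Compound 4 `NC1=NC2(CCOCC2)N(OCCCOc2ccccc2Br)C(N)=N1` differs from compound 3 by 2-bromophenyl in place of 4-chlorophenyl on an oxygen on a saturated carbon. Among the compounds with values here, no measured pair shows a halogen moving to a different ring position, nor bromo against chloro, so the two steps bear only loosely. The step of a 4.8-fold lower number from compound 2 to compound 3 (0.68 log units; beyond the scatter) suggests a heavier halogen does not hurt; the step of a 7.7-fold higher number from compound 1 to compound 3 (0.88 log units; beyond the scatter) shows the ring pattern can shift the number by a modest amount. Taken together, a step of no more than modest size in this assay is expected for compound 4, direction uncertain, a 1.3-fold higher number from compound 3 to compound 4 (0.12 log units; within the scatter). Compound 4 is estimated at 900 nM, with a range from 250 nM to 3500 nM.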

Compound 4, half-maximal inhibitory concentration: 30 nM
Beside the measured number, compound 4's estimate is 30-fold (1.48 log units) above it, and the stated range ends above it.
By their numbers in this assay, from the lowest: compound 4; then compound 1; then compound 3; then compound 2.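

In this assay, the change from 4-chlorophenyl to 2-bromophenyl gives the largest single-group gain around compound 3 (a 23-fold lower number from compound 3 to compound 4 (1.36 log units; beyond the scatter)), which shows that this position can move the number much further than the earlier halogen steps did. The spread at this position also widens (a 110-fold lower number from compound 2 to compound 4 (2.04 log units; beyond the scatter)), and a second halogen on the ring proves unnecessary for the lowest number in the set (a 3.0-fold lower number from compound 1 to compound 4 (0.48 log units; beyond the scatter)). No measurement at hand explains these steps.

The step to 2-bromophenyl changes the halogen and its ring position together, so the share of each cannot be separated. From the compounds shown here alone, how a methoxy or trifluoromethyl group on the aryl ring, or a longer chain to the aryloxy oxygen, would read remains open.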